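Boron for bromine on the hydrazide nitrogen of compound 1

The source may report more compounds than this note shows. Statements on the series, on what has been measured and on what is new or still open speak of the compounds shown alone.

Measured so far:
compound 1 `CC(C)CN(NC(=O)OCc1ccccc1)C(=O)CN(Cc1ccccc1)NC(=O)Cc1cccc(Br)c1`: > 80000 nM
compound 2 `CC(C)CN(CC(=O)N(CC(C)C)NC(=O)OCc1ccccc1)/N=C/c1ccccc1B(O)O`: 26300 nM

In a functional assay on B16 cells (Mus musculus) for inhibition (on this read-out higher numbers stand for weaker inhibition and lower numbers for stronger inhibition), compound 1 gives > 80000 nM, which is a limit of the assay and not a number (the limit of > 80000 nM in this assay, at which 1 of the 2 values shown sits). Compound 2 gives 26300 nM in this assay. For the measured compounds named here, these two compounds differ in more than one place, so no single step can be read from them; the values show only that compound 2 falls within the measurable range while compound 1 does not.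

Compound 3 `CC(C)CN(NC(=O)OCc1ccccc1)C(=O)CN(Cc1ccccc1)/N=C/c1cccc(B(O)O)c1` differs from compound 1 in one place: a group of 11 heavy atoms (7 carbon, 1 boron, 1 nitrogen, 2 oxygen; one six-membered aromatic ring of carbon only) in place of a group of 11 heavy atoms (8 carbon, 1 nitrogen, 1 oxygen, 1 bromine; one six-membered aromatic ring of carbon only), on an amine nitrogen.

Compound 2 also carries boron and gives 26300 nM in this assay. Against that background the step from compound 1 to compound 3 is expected to be an at least 2.0-fold lower number from compound 1 to compound 3 (0.30 log units; that floor lies within the scatter), towards stronger inhibition, though a second limit cannot be excluded. Compound 3 is therefore estimated at 40000 nM, with a range from 12000 nM to 120000 nM.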

Compound 3, half-maximal inhibitory concentration: 20400 nM
The estimate for compound 3 lay 2.0-fold (0.29 log units) above the measured number; the measured number falls inside the stated range.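

In this assay, the boron-bearing group in place of the bromine-bearing group, on an amine nitrogen of the shared core, gives an at least 3.9-fold lower number from compound 1 to compound 3 (0.59 log units; beyond the scatter). The true size of this step is not known, and its printed size is only a floor, since the value for compound 1 is a limit of the assay: the limit of > 80000 nM in this assay, at which 1 of the 3 values shown sits. Compound 2 could not show this, as it differs from compound 1 in more than one place, whereas compound 3 shows that this single change on this nitrogen moves the read-out into the measurable range.

The two groups differ in more than the boron and bromine atoms. The data do not show how much of the step goes with boron alone. Also open, going by these compounds, is whether a carboxylic acid on the same aromatic ring, in place of the boron-bearing function, would give a comparable number.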